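Chloro added to the amide aryl of compound 2

The source may report more compounds than this note shows. Statements on the series, on what has been measured and on what is new or still open speak of the compounds shown alone.

Compound 1: `COc1cc(-c2nn(-c3cccc(NC(=O)Nc4cc(C(F)(F)F)cc(C(F)(F)F)c4)c3)cc2-c2ccncc2)ccc1Cl`, 310 nM
Compound 2: `COc1cc(-c2nn(-c3cccc(NC(=O)c4cccc(C(F)(F)F)c4)c3)cc2-c2ccncc2)ccc1Cl`, 1570 nM

Of the compounds shown here, two sharing one core have been measured in a functional assay on RPMI-8226 cells (Homo sapiens) for inhibition, read by sulforhodamine B assay, with a stated time of 48 h; a lower number here means a stronger inhibitor, a higher number a weaker inhibitor. Compound 2 `COc1cc(-c2nn(-c3cccc(NC(=O)c4cccc(C(F)(F)F)c4)c3)cc2-c2ccncc2)ccc1Cl` gives 1570 nM, the higher of the two numbers. Compound 1 `COc1cc(-c2nn(-c3cccc(NC(=O)Nc4cc(C(F)(F)F)cc(C(F)(F)F)c4)c3)cc2-c2ccncc2)ccc1Cl` gives 310 nM, and the gap between the two lies beyond the usual scatter. Within the data shown here, no single-point step between the measured compounds is available, so that gap is not broken down further.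

Compound 3 `COc1cc(-c2nn(-c3cccc(NC(=O)c4ccc(Cl)c(C(F)(F)F)c4)c3)cc2-c2ccncc2)ccc1Cl` has not yet been measured. It differs from compound 2 by one change: chloro in place of hydrogen on an aromatic carbon. Among the measured compounds shown here, on the two numbers at hand alone, the author has no measured step of this kind to lean on. A step of modest size toward a lower number is expected, a 1.7-fold lower number from compound 2 to compound 3 (0.24 log units; within the scatter), though it may not exceed the scatter. Compound 3 is estimated at 900 nM, with a range from 300 nM to 2500 nM.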

Compound 3, half-maximal inhibitory concentration: 1620 nM
Compound 3: the middle estimate sits 1.8-fold (0.26 log units) below what was measured; low and high end bracket the measured number.
By their numbers in this assay, from the lowest: compound 1; then compounds 2 and 3 (each within the scatter of the next).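

In this assay, chloro in place of hydrogen on the amide aryl ring, ortho to a trifluoromethyl group, gives a 1.0-fold higher number from compound 2 to compound 3 (0.01 log units; within the scatter) and so does not separate compound 3 from compound 2. Among these compounds, this is the first single-point step available in the set, and it shows that this carbon of the ring accepts a chloro without any difference that can be read beyond the scatter, although that rests on this one pair. The compounds shown offer no measured evidence that could account for this result.

Going by these compounds, whether an amine or a methoxy group on this same carbon would shift the number beyond the scatter remains open. Also open, on these data alone, is whether chloro would behave the same way on the aryl ring of compound 1.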